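Two Limits and a Trifluoromethoxy Swap

This account rests on a few compounds, and the source may have more. Where it says the series, first, only, none or still open, it means among the compounds named here.

Measured in a functional assay on A549 cells (Homo sapiens) for inhibition, read by sulforhodamine B assay, with a stated time of 74 h; a lower number here means a stronger inhibitor, a higher number a weaker inhibitor:
Compound 1 `O=C1C=CC2(C=C1)OCC(=O)N2S(=O)(=O)c1ccccc1` gives > 10000 nM, a limit of the assay.
Compound 2 `Cc1ccccc1S(=O)(=O)N1C(=O)COC12C=CC(=O)C=C2` gives > 10000 nM, a limit of the assay.

Going by the values given here, compound 2 has no numerical value to stand on, and neither does compound 1, the only other compound measured. Among the compounds with values here, the one measured step is a step that the two limits leave unreadable from compound 1 to compound 2, so methyl in place of hydrogen on an aromatic carbon has no readable size. The evidence for the series is the limit of > 10000 nM in this assay, at which 2 of the 2 values shown sit.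

Compound 3 `O=C1C=CC2(C=C1)OCC(=O)N2S(=O)(=O)c1ccccc1OC(F)(F)F` carries trifluoromethoxy in place of methyl on an aromatic carbon, ortho to a large group: trifluoromethoxy in place of methyl on an aromatic carbon. Within the data shown here, no measured step covers this replacement, and the data give no direction for it. The expectation therefore rests on compound 2 with its limit of > 10000 nM, and no clear gain in this assay is expected. Another limit is the likeliest report. The expected change is a step that the limit leaves unreadable from compound 2 to compound 3, with no firm direction. For compound 3 the estimated value is 12000 nM, with an expected range from 3000 nM to 40000 nM.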

Compound 3, half-maximal inhibitory concentration: > 10000 nM
Compound 3 was reported as a limit (the forecaster's own chance of this, stated with the estimate: 70%); the middle value is on the limit's open side.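

Going by these compounds alone, compound 3 gives > 10000 nM in this assay, which is a limit of the assay, so no step among compound 1, compound 2 and compound 3 can be read. The compounds shown leave open whether methyl or trifluoromethoxy in place of hydrogen on the aromatic carbon changes inhibition at all, since the series offers only this: the limit of > 10000 nM in this assay, at which 3 of the 3 values shown sit.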